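Acetyl in place of hydrogen on the amino of compound 1

The compounds below may be only part of what the source reports. "The series", "measured", "known", "first", "only" and "open" are said of these compounds alone.

Two compounds of the series carry numbers in an assay for inhibition of Dihydrofolate reductase (Homo sapiens); on this read-out higher numbers stand for higher potency (the scale is a negative logarithm) and lower numbers for lower potency. Compound 1 `Nc1nc(O)c2cc(S(=O)(=O)c3ccc4ccccc4c3)ccc2n1` gives 7.96 in this assay, the higher of the two values. Compound 2 `Nc1nc(N)c2c(Cl)c(N)ccc2n1` gives 6.18 in this assay, and the gap between compound 2 and compound 1 lies beyond the usual scatter of this read-out. Compound 3 `CC(=O)Nc1nc(O)c2cc(S(=O)(=O)c3ccc4ccccc4c3)ccc2n1` has not yet been measured. It differs from compound 1 in one place: acetyl in place of hydrogen on a nitrogen on an aromatic ring, the same difference read one bond further out being amino to acetamido. Within the data shown here, no measured pair in the set covers a change of this kind, so nothing measured fixes its size. A drop rather than a gain is expected here, with the step from compound 1 to compound 3 estimated at a number 1.06 log units lower from compound 1 to compound 3 (beyond the scatter), larger than the scatter. Compound 3 is accordingly expected to give about 6.9 in this assay, within a range from 6 to 7.8.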

Compound 3, logarithm of the reciprocal of the active concentration, log(1/C): 6.11
Estimate against measurement, compound 3: 0.79 log units above; measured number inside the range.
By their numbers in this assay, from the lowest: compounds 3 and 2 (each within the scatter of the next); then compound 1.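

In this assay, among these compounds, the change from amino to acetamido gives a number 1.85 log units lower from compound 1 to compound 3 (beyond the scatter), a large step and the first reading at this position. With the rest of the core of compound 1 unchanged, the loss belongs to this single change: acetyl on the nitrogen on the aromatic ring is not tolerated without a clear drop in potency, and the hydrogen it replaces matters to the number. No measurement at hand bears on the reason for this loss.

From the compounds shown here alone, whether the drop is specific to acetyl or follows from any group on this nitrogen stays open. A methyl group, a longer acyl chain such as propionyl or a methanesulfonyl group at the same place would separate these readings.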